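Chain-Terminus Ring Swap on Compound 1

The source may report more compounds than this note shows. Statements on the series, on what has been measured and on what is new or still open speak of the compounds shown alone.

compound 1 `COc1cc2c(Oc3ccc(NC(=O)c4nnn(-c5ccc(C)cc5)c4C(F)(F)F)cc3F)ccnc2cc1OCCCN1CCCC1` — 790 nM
compound 2 `COc1cc2c(Oc3ccc(NC(=O)c4nnn(-c5ccccc5C(F)(F)F)c4C(F)(F)F)cc3F)ccnc2cc1OCCCN1CCCC1` — 270 nM

In a functional assay on NCI-H460 cells (Homo sapiens) for cytotoxicity, read by MTT assay, with a stated time of 72 h (a lower number here means a stronger inhibitor, a higher number a weaker inhibitor), compound 1 gives 790 nM, the highest of the two numbers shown. Its nearest neighbour is compound 2, which gives 270 nM; the step of a 2.9-fold lower number from compound 1 to compound 2 (0.47 log units; beyond the scatter) goes with 2-(trifluoromethyl)phenyl in place of 4-methylphenyl on an aromatic nitrogen. Compound 3 `COc1cc2c(Oc3ccc(NC(=O)c4nnn(-c5ccc(C)cc5)c4C(F)(F)F)cc3F)ccnc2cc1OCCCN1CCC(C)CC1` differs from compound 1 at a different site: 4-methylpiperidin-1-yl in place of pyrrolidin-1-yl on a saturated chain carbon, three bonds along the chain from an oxygen on an aromatic ring. For the measured compounds named here, the one measured step concerns the aryl group on the aromatic nitrogen and does not touch the chain terminus, so there is no measured step that bears on this change. For compound 3 the expected step is therefore no change at the digits printed from compound 1 to compound 3 (within the scatter), which is not beyond the scatter. Compound 3 is estimated at 790 nM, with a range from 300 nM to 2100 nM.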

Compound 3, half-maximal inhibitory concentration: 1250 nM
The estimate for compound 3 lay 1.6-fold (0.20 log units) below the measured number; the range from low to high includes it.
By their numbers in this assay, from the lowest: compound 2; then compounds 1 and 3 (each within the scatter of the next).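

At the end of the propyl chain, in this assay, 4-methylpiperidin-1-yl in place of pyrrolidin-1-yl gives a 1.6-fold higher number from compound 1 to compound 3 (0.20 log units; within the scatter). For the compounds shown here, this is the first reading at this position, and it shows that, in this pair, a six-membered ring carrying a methyl group can replace the five-membered ring with no step beyond the scatter. No measurement at hand explains this result.

The compounds shown leave open whether a plain piperidin-1-yl, a morpholin-4-yl or a dimethylamino group at the same chain end would read the same way, and so the ring size and the methyl group cannot be told apart. They also leave open whether the same exchange would hold on compound 2, with its 2-(trifluoromethyl)phenyl group.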